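The compounds below may be only part of what the source reports. "The series", "measured", "known", "first", "only" and "open" are said of these compounds alone.

Compound 1, with the structure `Cn1cnc2c(Nc3ccccc3)ncnc21`, was tested in an assay on isolated protein for inhibition of Ca2+/calmodulin-dependent protein kinase II (CaM kinase II) (Rattus norvegicus), tested at 30 uM (a lower number here means less inhibition, a higher number more inhibition at the concentration tested (going by the name of the read-out)), where compound 1 gives 0%. Compound 2, with the structure `Cn1cnc2c(Nc3ccc(F)cc3)ncnc21`, differs from compound 1 by one change, (fluoro in place of hydrogen on an aromatic carbon), and in this assay compound 2 gives 8%. The change produced a number 8 percentage points higher from compound 1 to compound 2 (within the scatter), so the two readings cannot be told apart with confidence.

Compound 3, with the structure `c1ccc(-[n+]2c[nH]c3ncncc32)cc1`, has a different core from compound 1; how the two cores differ is not broken down here. In this assay compound 3 gives 0%, level with compound 1 at the digits printed and within the scatter of compound 2.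

Compound 4, with the structure `Fc1ccc(-[n+]2c[nH]c3ncncc32)cc1`, has not yet been measured. It differs from compound 3 by fluoro in place of hydrogen on an aromatic carbon. Among the compounds with values here, this is the same kind of change as the one from compound 1 to compound 2, though the surroundings are not identical: in compound 4 the fluoro sits para to a group of 9 heavy atoms, whereas in compound 2 it sits para to a large group.

For compound 4 the expected step in this assay is a number 5 percentage points higher from compound 3 to compound 4 (within the scatter), a small move, because the same kind of change earlier gave a number 8 percentage points higher from compound 1 to compound 2 (within the scatter). The expectation rests on one pair only, so it is tentative. Compound 4 is therefore estimated at 5%, most likely between -8% and 18%.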

Compound 4, a percentage reported as inhibition, at one concentration (the size of the read-out at that concentration, not a potency): 0%
Beside the measured number, compound 4's estimate is 5 percentage points above it, and the stated range covers the measured number.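

In this assay, placing a fluoro on the aromatic carbon of compound 3 gives no change at the digits printed from compound 3 to compound 4 (within the scatter), so the change leaves no detectable mark on this core. Set beside the earlier step, the same change gives no sign of behaving differently on the two cores: the same change on two cores in this assay, a number 8 percentage points higher (within the scatter) from compound 1 to compound 2 and no change at the digits printed (within the scatter) from compound 3 to compound 4, 8 percentage points apart, within the scatter of two such steps. This agreement is weak support for carrying the change from one core to another, since neither step stands clear of the scatter: it shows that the fluoro produced no measurable effect on either core, not that a real effect was transferred, and two cores at a single test concentration say nothing about potency or about what would happen on a core with clear inhibition.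

The compounds shown leave open whether any group in that place on the ring, such as an amine, a carboxylic acid or a longer chain, would lift the reading beyond the scatter on either core. They also leave open whether a change that did produce a clear step on one core would produce a similar step on the other.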